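The compounds below may be only part of what the source reports. "The series", "measured", "known", "first", "only" and "open" are said of these compounds alone.

Measured in an ADME assay on HepG2 2.2.15 cells (Homo sapiens) for cytotoxicity; a lower number here means that less compound is tolerated, a higher number that more compound is tolerated:
- compound 1 `O=C(O)CCCC(=O)OCCc1c(-c2ccccc2Cl)c2cc(Cl)ccc2[nH]c1=O`: 110000 nM.
- compound 2 `O=C(OCCc1c(-c2ccccc2Cl)c2cc(Cl)ccc2[nH]c1=O)C1CCCCC1`: 38000 nM.
- compound 3 `CC12CCC(C(=O)OCCc3c(-c4ccccc4Cl)c4cc(Cl)ccc4[nH]c3=O)(OC1=O)C2(C)C`: > 1800000 nM, a limit and not a number.

Compound 3 stands only at a limit, (the limit of > 1800000 nM in this assay, at which 1 of the 3 values shown sits). Its true value is therefore unknown, and any step away from it carries that uncertainty.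

The next compound is compound 4 `CC(=O)N1CCC(C(=O)OCCc2c(-c3ccccc3Cl)c3cc(Cl)ccc3[nH]c2=O)CC1`, with the change (a group of 9 heavy atoms (7 carbon, 1 nitrogen, 1 oxygen; one six-membered non-aromatic ring with 1 hetero atom) in place of a group of 11 heavy atoms (9 carbon, 2 oxygen; one five-membered non-aromatic ring of carbon only, one five-membered non-aromatic ring with 1 hetero atom), on a carbonyl carbon). The bicyclic group on the carbonyl carbon gives way to 1-acetylpiperidin-4-yl.

Three measured steps at this same place bear on the change. Two are large: an at least 16-fold higher number from compound 1 to compound 3 (1.21 log units; beyond the scatter) and an at least 47-fold higher number from compound 2 to compound 3 (1.67 log units; beyond the scatter). The third is only modest: a 2.9-fold lower number from compound 1 to compound 2 (0.46 log units; beyond the scatter). Thus the two groups other than that of compound 3 lie fairly close together, and compound 3 stands well apart from them. Compound 2 also has a six-membered ring here, so a large step to a lower number is expected in this assay, roughly reversing an at least 47-fold higher number from compound 2 to compound 3 (1.67 log units; beyond the scatter).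

The expected change is an at least 18-fold lower number from compound 3 to compound 4 (1.25 log units; beyond the scatter).

Compound 4 is estimated at 100000 nM, with an expected range of 30000 nM to 600000 nM.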

Compound 4, half-maximal cytotoxic concentration: 82000 nM
For compound 4 the middle estimate is 1.2-fold (0.09 log units) above the measured one, within the range that was stated.
By their numbers in this assay, from the lowest: compound 2; then compounds 4 and 1 (each within the scatter of the next). At a limit, above all of these: compound 3.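

In this assay, replacing the bicyclic group with 1-acetylpiperidin-4-yl gives an at least 21-fold lower number from compound 3 to compound 4 (1.34 log units; beyond the scatter), so a second six-membered ring, this one with a hetero atom, also falls far short of compound 3. On these data alone, compound 3 is known only as a limit, so the true size of that step remains unknown: the limit of > 1800000 nM in this assay, at which 1 of the 4 values shown sits. The new group sits closer to the other two, with a 2.2-fold higher number from compound 2 to compound 4 (0.33 log units; beyond the scatter) against cyclohexyl, a modest step, and a 1.3-fold lower number from compound 1 to compound 4 (0.13 log units; within the scatter) against 3-carboxypropyl.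

Still open, as far as these compounds go, is which part of the group in compound 3 sets it apart, the five-membered ring of carbon only or the five-membered ring with a hetero atom. Also open, from the compounds shown here alone, is where a free amine in place of the acetylated ring nitrogen, or a chain longer than 3-carboxypropyl, would fall in this assay.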